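Changing the sulfur substituent from compound 2 to compound 3

The source may hold more compounds than are shown below. What is called first, only, known or untested is meant among the compounds shown, and "the series" means these compounds.

Compound 1 `O=C(/C(=C\c1ccc(O)c([N+](=O)[O-])c1)SCc1ccccc1Cl)c1ccc(Cl)cc1` gives 10000 nM
Compound 2 `O=C(/C(=C\c1ccc(Cl)cc1)SCc1ccccc1Cl)c1ccc(Cl)cc1` gives 12000 nM

In a functional assay on DU-145 cells (Homo sapiens) for inhibition, read by trypan blue exclusion, with a stated time of 96 h (a higher number here means a weaker inhibitor of growth, a lower number a stronger inhibitor of growth), compound 2 stands at 12000 nM, within the scatter of compound 1. Compound 3 `O=C(/C(=C\c1ccc(Cl)cc1)Sc1ccc(Cl)cc1)c1ccc(Cl)cc1` keeps the rest of compound 2 and changes one group: 4-chlorophenyl in place of 2-chlorobenzyl on a sulfur. In words, this is 4-chlorophenyl in place of 2-chlorobenzyl on a sulfur.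

Going by the values given here, the only measured step, a 1.2-fold higher number from compound 1 to compound 2 (0.08 log units; within the scatter), lies at a different place and leaves the sulfur group untouched. It therefore gives no direct guide to the size or direction of this change. With no measured evidence for a shift, no step beyond the scatter is expected in this assay, and the range is kept wide. The expected step is a 1.2-fold lower number from compound 2 to compound 3 (0.08 log units; within the scatter). For compound 3 the estimate is 10000 nM, with an expected range of 3500 nM to 30000 nM.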

Compound 3, concentration for 50% growth inhibition: 1000 nM
Estimate against measurement, compound 3: 10-fold (1.00 log units) above; measured number outside the range, below it.
By their numbers in this assay, from the lowest: compound 3; then compounds 1 and 2 (each within the scatter of the next).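

In this assay, going by these compounds alone, the sulfur substituent proves to be a place where one change moves the read-out well beyond the scatter: 4-chlorophenyl in place of 2-chlorobenzyl gives the largest step so far (a 12-fold lower number from compound 2 to compound 3 (1.08 log units; beyond the scatter)). Within the data shown here, the earlier change on the double-bonded chain carbon stayed within the scatter (a 1.2-fold higher number from compound 1 to compound 2 (0.08 log units; within the scatter)), so the sulfur group is the first position here with a measurable effect on growth inhibition. No measured evidence bears on why this change has such an effect.

This single step combines the loss of the benzyl carbon with a new chlorine position, and the compounds shown do not separate the two. Open too, on these data alone, are 4-chlorobenzyl and 2-chlorophenyl on the sulfur, and whether a phenyl ring carrying an amine or a carboxylic acid there would hold the lower number.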